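Benzoyl in place of methoxy on the aryl-triazole

This account rests on a few compounds, and the source may have more. Where it says the series, first, only, none or still open, it means among the compounds named here.

Three compounds of the series have numbers in a functional assay on MIA PaCa-2 cells (Homo sapiens) for inhibition, read by MTT assay, with a stated time of 72 h, tested at 30 uM; a higher number here means more inhibition of growth at the concentration tested, a lower number less inhibition of growth. Compound 1 `C=CCc1ccc(OCc2cn(-c3ccc(C#N)cc3)nn2)c(O)c1` gives 39.3%, compound 2 `C=CCc1ccc(OCc2cn(-c3ccc(OC)cc3)nn2)c(O)c1` gives 62.3%, and compound 3 `C=CCc1ccc(OCc2cn(-c3ccccc3CO)nn2)c(O)c1` gives 39.6%. Compound 2 stands highest of the three: the step of a number 22.7 percentage points lower from compound 2 to compound 3 (beyond the scatter) and the step of a number 23 percentage points higher from compound 1 to compound 2 (beyond the scatter) both lie beyond the scatter, while compounds 1 and 3 sit within the scatter of each other.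

Compound 4 `C=CCc1ccc(OCc2cn(-c3ccc(C(=O)c4ccccc4)cc3)nn2)c(O)c1` differs from compound 2 in one place: benzoyl in place of methoxy on an aromatic carbon. The step that bears most directly on this change is a number 23 percentage points higher from compound 1 to compound 2 (beyond the scatter), where the same position carried cyano instead of methoxy and the number was modestly lower. The step of a number 22.7 percentage points lower from compound 2 to compound 3 (beyond the scatter) shows that a second departure from the methoxy-bearing aryl also lowered the number modestly. Among the measured compounds shown here, no measured compound carries benzoyl at this position, so the direction rests only on the observation that both departures from compound 2 cost about the same amount.

A modest drop is therefore expected. For compound 4 the estimate in this assay is 45%, with a range from 25% to 65%, which corresponds to an expected step of a number 17.3 percentage points lower from compound 2 to compound 4 (beyond the scatter).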

Compound 4, percent growth inhibition at one concentration: 40.1%
Estimate against measurement, compound 4: 4.9 percentage points above; the measured number falls inside the stated range.
By their numbers in this assay, from the lowest: compounds 1, 3 and 4 (each within the scatter of the next); then compound 2.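

In this assay, benzoyl brings 8 heavy atoms and one more six-membered aromatic ring where methoxy has 2 heavy atoms and no ring, and the change gives a number 22.2 percentage points lower from compound 2 to compound 4 (beyond the scatter), so this position takes a much larger group without a reading below that of the cyano compound. Against cyano, the same exchange gives a number 0.8 percentage points higher from compound 1 to compound 4 (within the scatter), which leaves these two groups indistinguishable here and makes methoxy the only one of the three groups at this position with the higher reading. No measurement among the data gives a reason for methoxy standing apart from cyano and benzoyl.

On these data alone, whether the higher reading belongs to methoxy alone or carries over to ethoxy, a hydroxyl, a dimethylamino group or a carboxylic acid at the same place remains open. Also open, as far as these compounds go, is whether a smaller carbonyl group such as acetyl would read like benzoyl, and whether the differences seen at the single concentration of this assay would hold across a full concentration series.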